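Cytotoxicity notes on the pyrimidinyl amine pair

The source may report more compounds than this note shows. Statements on the series, on what has been measured and on what is new or still open speak of the compounds shown alone.

Measured so far:
compound 1 `C[C@@H](Cn1ccc(-c2ccc(C#N)c(Cl)c2)n1)NC(=O)C1CC(=O)C1`: > 30000 nM
compound 2 `C[C@@H](Cn1ccc(-c2ccc(C#N)c(Cl)c2)n1)Nc1ccccn1`: "not determined" (no result reported)
compound 3 `C[C@@H](Cn1ccc(-c2ccc(C#N)c(Cl)c2)n1)Nc1cncnc1`: > 30000 nM

In an ADME assay on PC-3 cells (Homo sapiens) for cytotoxicity, read by CCK-8 assay, with a stated time of 6 days (a lower number here means a stronger inhibitor, a higher number a weaker inhibitor), compound 1 gives only a limit, > 30000 nM. Compound 3 likewise gives only a limit in this assay, > 30000 nM. Both values sit at the limit of > 30000 nM in this assay, at which 2 of the 3 values shown sit, so the step that the two limits leave unreadable from compound 1 to compound 3 cannot be read. For compound 2 this assay records "not determined" (no result reported). Compound 4 `Cc1ccnc(N[C@@H](C)Cn2ccc(-c3ccc(C#N)c(Cl)c3)n2)n1` differs from compound 3 by 4-methylpyrimidin-2-yl in place of pyrimidin-5-yl on an amine nitrogen. Going by the values given here, no measured step bears on this change; the one step in hand is unreadable, and compound 3 itself stands at a limit. The step of a number no higher from compound 3 to compound 4 (the limit leaves the size open) is therefore expected to be none beyond the scatter. Compound 4 is expected near 30000 nM, within 10000 nM to 100000 nM, most likely again reported as a limit.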

Compound 4, half-maximal inhibitory concentration: > 30000 nM
Compound 4 was reported as a limit (the forecaster's own chance of this, stated with the estimate: 75%); the middle value lies on the limit itself.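

No new step can be read among compound 1, compound 3 and compound 4 in this assay, as each value is only a limit: the limit of > 30000 nM in this assay, at which 3 of the 4 values shown sit.

The compounds shown leave open whether any change on the amine nitrogen gives a measurable value in this assay.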